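Fluoro Enters the Fused Ring System of Compound 3

The source may report more compounds than this note shows. Statements on the series, on what has been measured and on what is new or still open speak of the compounds shown alone.

Compound 3 `CCC/C=C\C(=O)Nc1cc(Nc2ncc(C#N)c(-c3cn(C)c4ccccc34)n2)c(OC)cc1N(C)CCN(C)C` gives 166 nM in a functional assay on A549 cells (Homo sapiens) for antiproliferative activity, read by MTT assay, with a stated time of 72 h; a lower number here means a stronger inhibitor, a higher number a weaker inhibitor. Among the three measured compounds this is the second highest number: compound 1 `CC/C=C\C(=O)Nc1cc(Nc2ncc(C#N)c(-c3cn(C)c4ccccc34)n2)c(OC)cc1N(C)CCN(C)C` gives 162 nM, which lies within the scatter of compound 3, while compound 2 `COc1cc(N(C)CCN(C)C)c(NC(=O)/C=C\C(C)C)cc1Nc1ncc(C#N)c(-c2cn(C)c3ccccc23)n1` gives 1100 nM, and the step of a 6.6-fold lower number from compound 2 to compound 3 (0.82 log units; beyond the scatter) lies beyond the scatter. Compound 4 `CCC/C=C\C(=O)Nc1cc(Nc2ncc(C#N)c(-c3cn(C)c4ccc(F)cc34)n2)c(OC)cc1N(C)CCN(C)C` differs from compound 3 by fluoro in place of hydrogen on an aromatic carbon. The measured steps, a 6.8-fold higher number from compound 1 to compound 2 (0.83 log units; beyond the scatter) and a 1.0-fold higher number from compound 1 to compound 3 (0.01 log units; within the scatter) among them, all concern the chain bearing the double bond and not the fused ring system, so none of them bears on this change. Without such a guide, the expected step of a 1.0-fold higher number from compound 3 to compound 4 (0.01 log units; within the scatter) is none beyond the scatter. Compound 4 is therefore estimated at 170 nM, with a range from 60 nM to 480 nM.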

Compound 4, half-maximal inhibitory concentration: 741 nM
Compound 4: middle estimate off by 4.4-fold (0.64 log units), on the low side, outside the stated range (above it).
By their numbers in this assay, from the lowest: compounds 1 and 3 (each within the scatter of the next); then compounds 4 and 2 (each within the scatter of the next).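

For the compounds shown here, the earlier steps all lay in the chain bearing the double bond, so this is the first sign that the fused ring system also matters in this assay. A single fluoro in place of hydrogen on an aromatic carbon gives a 4.5-fold higher number from compound 3 to compound 4 (0.65 log units; beyond the scatter), so even this small change weakens the compound. Nothing available here accounts for the loss. The compounds shown leave open whether chloro, methoxy or an amine on this same carbon would cost as much, and whether fluoro elsewhere on this ring would.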